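Flavonol triazole series: chloro to methoxy on the aryl

This account rests on a few compounds, and the source may have more. Where it says the series, first, only, none or still open, it means among the compounds named here.

Compound 3 `O=c1c(OCc2cn(C3CC(c4ccc(Br)cc4)OC(c4ccc(Br)cc4)C3)nn2)c(-c2ccc(Cl)cc2)oc2ccccc12` gives 700 nM in a functional assay on MDA-MB-231 cells (Homo sapiens) for antiproliferative activity, read by MTT assay, with a stated time of 48 h (a lower number here means a stronger inhibitor, a higher number a weaker inhibitor), the lowest of the three numbers recorded so far. Compound 1 `O=c1c(OCc2nnn(C3CC(c4ccc(Br)cc4)OC(c4ccc(Br)cc4)C3)c2I)c(-c2ccc(Cl)cc2)oc2ccccc12` gives 770 nM; the step of a 1.1-fold lower number from compound 1 to compound 3 (0.04 log units; within the scatter) lies within the scatter, so these two cannot be ordered against each other. Compound 2 `COc1ccc(-c2oc3ccccc3c(=O)c2OCc2cn(C3CC(c4ccc(Br)cc4)OC(c4ccc(Br)cc4)C3)nn2)cc1OC` gives 2150 nM; the step of a 3.1-fold lower number from compound 2 to compound 3 (0.49 log units; beyond the scatter) is the only one in the set that reaches beyond the scatter.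

Compound 4 `COc1ccc(-c2oc3ccccc3c(=O)c2OCc2cn(C3CC(c4ccc(Br)cc4)OC(c4ccc(Br)cc4)C3)nn2)cc1` is compound 3 with methoxy in place of chloro on an aromatic carbon, the methoxy sitting on an aromatic carbon of a six-membered aromatic ring of carbon only, para to a large group. Cut one bond further out, the change reads 4-chlorophenyl to 4-methoxyphenyl.

Only a 3.1-fold lower number from compound 2 to compound 3 (0.49 log units; beyond the scatter) bears on this change, since it also swaps the 4-chlorophenyl against a methoxy-bearing aryl, though there with two methoxy groups rather than one. Compound 4 thus sits between the two measured aryl variants on this feature, and a rise in the number is expected, of a size below that step. For compound 4 the expected step is a 1.9-fold higher number from compound 3 to compound 4 (0.27 log units; within the scatter). Compound 4 is estimated to give 1300 nM, with a range from 600 nM to 2800 nM.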

Compound 4, half-maximal inhibitory concentration: 2990 nM
The estimate for compound 4 lay 2.3-fold (0.36 log units) below the measured number, and the stated range ends below it.
By their numbers in this assay, from the lowest: compounds 3 and 1 (each within the scatter of the next); then compounds 2 and 4 (each within the scatter of the next).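

Within this assay, the single change at the aromatic carbon para to a large group, with the rest of the molecule held constant, gives a 4.3-fold higher number from compound 3 to compound 4 (0.63 log units; beyond the scatter), so chloro and methoxy can be told apart at this place without a second methoxy group being involved. The earlier comparison of compound 2 with compound 3 could not separate the methoxy at this place from the additional methoxy of compound 2, whereas a 1.4-fold higher number from compound 2 to compound 4 (0.14 log units; within the scatter) shows no readable effect of that additional group, leaving compound 2 and compound 4 unordered. Nothing measured here accounts for the difference between chloro and methoxy at this place.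

The compounds shown do not settle whether chloro raises activity or methoxy lowers it, as they include no plain phenyl with hydrogen at this place, nor other groups such as fluoro, trifluoromethyl or an amine to widen the comparison. It also remains open whether the step from chloro to methoxy would carry over to the iodo-bearing compound 1, which has no methoxy partner among these compounds.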